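Aryl Versus Tert-Butyl at the Benzylic Position

A few compounds are considered here, and "the series" means these few. Any claim that something is new, unique, unknown or untested is made for them only; others in the source may bear on it.

The measured compounds:
compound 1 `COc1ccc(Cc2cnc(CCc3ccc(-c4ccccc4C(=O)O)cc3)[nH]2)cc1` gives 513 nM
compound 2 `O=C(O)c1ccccc1-c1ccc(CCc2ncc(Cc3ccccc3Cl)[nH]2)cc1` gives 22 nM
compound 3 `CC(C)(C)Cc1cnc(CCc2ccc(-c3ccccc3C(=O)O)cc2)[nH]1` gives 6.3 nM

These three share one core and differ only in the group on a saturated chain carbon bound to an aromatic carbon. In an in vitro functional assay on cells for agonist activity at Bombesin receptor subtype-3 (Mus musculus), read by luminescence and calcium flux (a higher number here means that more compound is needed for the effect, a lower number that less compound is needed), compound 3 gives 6.3 nM, the lowest of the three numbers. The step of an 81-fold lower number from compound 1 to compound 3 (1.91 log units; beyond the scatter) and the step of a 3.5-fold lower number from compound 2 to compound 3 (0.54 log units; beyond the scatter) are both beyond the scatter, and the step of a 23-fold lower number from compound 1 to compound 2 (1.37 log units; beyond the scatter) shows that the two aryl groups themselves differ clearly.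

Compound 4 `O=C(O)c1ccccc1-c1ccc(CCc2ncc(Cc3ccc(F)cc3)[nH]2)cc1` is unmeasured. Relative to compound 3 it carries 4-fluorophenyl in place of tert-butyl on a saturated chain carbon bound to an aromatic carbon. Both measured steps away from compound 3 bear on this: replacing tert-butyl by an aryl group raised the number in each case, by a modest amount for the 2-chlorophenyl and by a large amount for the 4-methoxyphenyl. A 4-fluorophenyl is closer in pattern to the 4-methoxyphenyl of compound 1 than to the 2-chlorophenyl of compound 2, so a sizeable rise is expected, most likely between those two outcomes. Compound 4 is therefore estimated at 100 nM, within 25 nM to 400 nM, a step of a 16-fold higher number from compound 3 to compound 4 (1.20 log units; beyond the scatter) expected.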

Compound 4, half-maximal effective concentration: 50 nM
Compound 4: middle estimate off by 2.0-fold (0.30 log units), on the high side; low and high end bracket the measured number.
By their numbers in this assay, from the lowest: compound 3; then compound 2; then compound 4; then compound 1.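

With a third aryl group now in hand, the advantage of tert-butyl on this saturated chain carbon no longer rests on two examples: in this assay the change to 4-fluorophenyl gives a 7.9-fold higher number from compound 3 to compound 4 (0.90 log units; beyond the scatter) and so, like 2-chlorophenyl and 4-methoxyphenyl, leaves the number higher than with tert-butyl, with no aryl group among the four compounds going against this. The aryl groups also separate further, since the swap of methoxy for fluoro on an aromatic carbon alone gives a 10-fold lower number from compound 1 to compound 4 (1.01 log units; beyond the scatter) while the 4-fluorophenyl still stands behind the 2-chlorophenyl, with a 2.3-fold higher number from compound 2 to compound 4 (0.36 log units; beyond the scatter) as the step, so the substituent and not merely the presence of an aryl ring governs the outcome among these groups. The data shown offer no measurement that explains any of these differences.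

From the compounds shown here alone, it remains open where an unsubstituted phenyl would fall among the aryl groups, and whether a 2-fluorophenyl or a 4-chlorophenyl would separate the effect of the halogen from that of its place on the ring. Also open, going by these compounds, is whether a cyclohexyl or a longer chain such as n-butyl would match tert-butyl at this position.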